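The compounds below may be only part of what the source reports. "The series", "measured", "known", "first", "only" and "open" are said of these compounds alone.

- Compound 1 `O=C(/C(=C\c1ccc(O)c([N+](=O)[O-])c1)SCc1ccc(Br)cc1)c1c(F)c(F)c(F)c(F)c1F`: 10000 nM
- Compound 2 `O=C(/C(=C\c1ccc(O)c([N+](=O)[O-])c1)SCc1ccc(Br)cc1)c1ccc(Cl)cc1Cl`: 10000 nM
- Compound 3 `O=C(/C(=C\c1c(O)cc(O)cc1O)Sc1ccc(Br)cc1)c1ccc(Cl)cc1`: 50000 nM

All three compounds were tested in a functional assay on DU-145 cells (Homo sapiens) for inhibition, read by trypan blue exclusion, with a stated time of 96 h; a lower number here means a stronger inhibitor of growth, a higher number a weaker inhibitor of growth. Compound 2 stands level with compound 1, and together they hold the lowest of the three numbers. Compound 3 has a higher number than either.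

Compound 4 `O=C(/C(=C\c1ccc(O)c([N+](=O)[O-])c1)SCc1ccc(Br)cc1)C1CCNC1` has not been measured. It keeps the rest of compound 2 and changes one group: pyrrolidin-3-yl in place of 2,4-dichlorophenyl on a carbonyl carbon. Here pyrrolidin-3-yl sits in place of 2,4-dichlorophenyl on a carbonyl carbon.

Among the compounds with values here, only one measured step falls at this place, the exchange of one phenyl group for another: no change at the digits printed from compound 1 to compound 2 (within the scatter). Within the data shown here, no measured compound carries a non-aromatic ring there, so that step is only a weak guide. The expectation is therefore no step beyond the scatter in this assay, with a wide range that leans towards a higher number.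

The estimated change is a 1.5-fold higher number from compound 2 to compound 4 (0.18 log units; within the scatter). For compound 4 the expected value is 15000 nM, with an estimated range of 4000 nM to 60000 nM.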

Compound 4, concentration for 50% growth inhibition: > 100000 nM
Compound 4: only a limit was reported; the forecaster's own chance of this, stated with the estimate: 15%; middle value at least 6.6-fold (0.82 log units) from the limit.
By their numbers in this assay, from the lowest: compounds 1 and 2 (each within the scatter of the next); then compound 3. At a limit, above all of these: compound 4.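

In this assay compound 4 gives > 100000 nM, which is a limit of the assay and not a number. Pyrrolidin-3-yl brings an at least 10-fold higher number from compound 2 to compound 4 (1.00 log units; beyond the scatter) when it replaces 2,4-dichlorophenyl, and an at least 10-fold higher number from compound 1 to compound 4 (1.00 log units; beyond the scatter) when it replaces 2,3,4,5,6-pentafluorophenyl. One aromatic ring exchanged for another had shown no change at the digits printed from compound 1 to compound 2 (within the scatter), so only this new exchange reveals that the group on the carbonyl carbon can strongly affect growth inhibition in these compounds.

How far compound 4 lies from compounds 1 and 2 stays open: the limit of > 100000 nM in this assay, at which 1 of the 4 values shown sits. The compounds shown also do not separate the loss of the aromatic ring from the arrival of the ring nitrogen, a question that a cyclohexyl ring or an unsubstituted phenyl ring on the carbonyl carbon could address.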